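The source may report more compounds than this note shows. Statements on the series, on what has been measured and on what is new or still open speak of the compounds shown alone.

Compound 1, `CC(C)[C@H](NC(=O)COc1cccc2ccccc12)C(=O)N[C@@H](CC(=O)O)C(=O)CSc1nc(-c2ccccc2)c(-c2ccccc2)[nH]1`: in a functional assay on Jurkat cells (Homo sapiens) for inhibition (a lower number here means a stronger inhibitor, a higher number a weaker inhibitor), compound 1 gives > 200000 nM, which is a limit of the assay and not a number.
Compound 2, `CC(C)[C@H](NC(=O)COc1cccc2ccccc12)C(=O)N[C@@H](CC(=O)O)C(=O)CSc1nc(-c2ccccc2)no1`: in this assay compound 2 gives 102000 nM.
Compound 3, `CC(C)[C@H](NC(=O)COc1cccc2ccccc12)C(=O)N[C@@H](CC(=O)O)C(=O)CSc1nc[nH]n1`: in this assay compound 3 gives > 200000 nM, which again is a limit of the assay and not a number.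

All three compounds share the same core and differ only in the group attached through sulfur at the end of the chain. Among the compounds with values here, compound 3 sits at the limit of this assay, so only its weak end is known; (the limit of > 200000 nM in this assay, at which 2 of the 3 values shown sit), and the one numeric value, that of compound 2, lies close to that limit. Within the data shown here, the single measured step, an at least 1.9-fold higher number from compound 2 to compound 3 (0.29 log units; that floor lies within the scatter), has a floor within the scatter, so it cannot be read as a real change.

Compound 4, `CC(C)[C@H](NC(=O)COc1cccc2ccccc12)C(=O)N[C@@H](CC(=O)O)C(=O)COc1ccccn1`, replaces the whole sulfur-linked group: (pyridin-2-yl)oxy in place of (1H-1,2,4-triazol-3-yl)sulfanyl on a saturated chain carbon bound to a carbonyl carbon. Among the measured compounds shown here, no measured step covers a change of this kind, so the only guidance is that every group tried on the chain end so far has left this assay values at or near the limit. Compound 4 is therefore expected to remain weak, with the step of an at least 1.3-fold lower number from compound 3 to compound 4 (0.12 log units; that floor lies within the scatter) expected to lie within the scatter, and a fair chance that compound 4 again returns only a limit. Compound 4 is estimated at 150000 nM, within 30000 nM to 400000 nM.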

Compound 4, half-maximal inhibitory concentration: > 200000 nM
Compound 4 was reported as a limit; the forecaster's own chance of this, stated with the estimate: 55%; middle value at least 1.3-fold (0.12 log units) away from the limit.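

Compound 4 also sits at the limit of this assay, and it does so with (pyridin-2-yl)oxy on this saturated chain carbon, so the link through sulfur and the five-membered aromatic ring of compound 3 can both be replaced without a measurable value appearing: the limit of > 200000 nM in this assay, at which 3 of the 4 values shown sit.

Steps that join two limits, including the one that links compound 3 to compound 4, cannot be read. The one readable step, an at least 1.9-fold higher number from compound 2 to compound 4 (0.29 log units; that floor lies within the scatter), gives no real change, so even the single numeric value in the set is not shown to stand apart from this new result.

The compounds shown leave open whether any group on this chain carbon can give a value well clear of the limit, or whether the shared core keeps every member of the series weak in this cell assay. A phenoxy group or an amine at this place would extend the comparison, and only a value that is a number would allow a step of real size to be read.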